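Series notes: isobutyl for isopropyl at the amide-bearing carbon

The source may report more compounds than this note shows. Statements on the series, on what has been measured and on what is new or still open speak of the compounds shown alone.

Activity is read in a functional assay on RAW264.7 cells (Mus musculus) for inhibition, read by microscopy and resazurin assay, with a stated time of 72 h; a lower number here means a stronger inhibitor, a higher number a weaker inhibitor. Compound 1 `COC(=O)[C@H](CC(C)C)NC(=O)c1cccc(/C=C2\SC(=O)N(CC(=O)NOCc3ccccc3)C2=O)c1` and compound 2 `COC(=O)[C@@H](NC(=O)c1cccc(/C=C2\SC(=O)N(CC(=O)NOCc3ccccc3)C2=O)c1)C(C)C` share one core. In this assay compound 1 gives only a limit of the assay, > 128000 nM. Compound 2 likewise gives only a limit, > 128000 nM. Between them the change is isobutyl in place of isopropyl on a saturated chain carbon bound to an amide-type nitrogen and a carbonyl carbon, and the step it makes is a step that the two limits leave unreadable from compound 2 to compound 1. Compound 3 `C=CCONC(=O)Cn1cc(C(=O)N[C@@H](C)C(=O)N[C@H](C(=O)O)C(C)C)c2ccccc21` carries a different core; the difference between the two cores is not broken down here. Compound 3 also gives only a limit, > 128000 nM. All measured values sit at the limit of > 128000 nM in this assay, at which 3 of the 3 values shown sit. Compound 4 `C=CCONC(=O)Cn1cc(C(=O)N[C@@H](C)C(=O)N[C@@H](CC(C)C)C(=O)O)c2ccccc21` is compound 3 changed by isobutyl in place of isopropyl on a saturated chain carbon bound to an amide-type nitrogen and a carbonyl carbon, the same change as between compound 2 and compound 1, at the same kind of carbon. Set beside the earlier step, the step from compound 3 to compound 4 is expected to be a step that the limit leaves unreadable from compound 3 to compound 4, because the limit of > 128000 nM in this assay, at which 3 of the 3 values shown sit, is where all three measured values sit and the earlier step could not be read. Compound 4 is therefore expected at 200000 nM, with a range of 60000 nM to 1000000 nM, most likely again as a limit only.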

Compound 4, half-maximal inhibitory concentration: > 128000 nM
Compound 4 was reported as a limit (the forecaster's own chance of this, stated with the estimate: 85%); the middle value is on the limit's open side.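

In this assay, among these compounds, compound 3 and compound 4 both give only a limit of the assay, and the step between them cannot be read, no more than the one between compound 2 and compound 1. The compounds shown leave open whether isobutyl in place of isopropyl alters inhibition on either core, with every reading at one limit: the limit of > 128000 nM in this assay, at which 4 of the 4 values shown sit.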